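The source may hold more compounds than are shown below. What is called first, only, known or untested is meant among the compounds shown, and "the series" means these compounds.

Values in a functional assay on A-375 cells (Homo sapiens) for cytotoxicity, read by CCK-8 assay, with a stated time of 24 h; on this read-out higher numbers stand for weaker inhibition and lower numbers for stronger inhibition:
Compound 1 `COc1cccc(-c2nc(N)c(Oc3ccccc3OC)c(Cl)n2)c1`: 24600 nM
Compound 2 `COc1ccccc1Oc1c(N)nc(-c2ccccc2F)nc1Cl`: > 80000 nM, a limit of the assay
Compound 3 `COc1ccccc1Oc1c(N)nc(-c2ccccc2F)nc1OCCO`: > 80000 nM, a limit of the assay

Compound 3 gives no true number in this assay: it stands at the limit of > 80000 nM in this assay, at which 2 of the 3 values shown sit. Compound 4 `COc1ccccc1Oc1c(N)nc(-c2ccc(Br)cc2)nc1OCCO` carries 4-bromophenyl in place of the 2-fluorophenyl of compound 3 (4-bromophenyl in place of 2-fluorophenyl on an aromatic carbon). This group sits on an aromatic carbon between two ring nitrogen atoms.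

Within the data shown here, only one readable step touches this place: an at least 3.2-fold higher number from compound 1 to compound 2 (0.51 log units; beyond the scatter), with 2-fluorophenyl in place of 3-methoxyphenyl. Among the measured compounds shown here, it shows that the aryl group here can move the number by at least a modest amount, though no measured compound carries 4-bromophenyl. The other step, a step that the two limits leave unreadable from compound 2 to compound 3, concerns the change from chloro to 2-hydroxyethoxy and gives no size to work with.

A modest move towards a lower number is therefore expected, with a real chance that the value stays at the limit. The expected change is an at least 1.6-fold lower number from compound 3 to compound 4 (0.20 log units; that floor lies within the scatter). For compound 4 the estimate is 50000 nM, with an expected range of 15000 nM to 90000 nM.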

Compound 4, half-maximal inhibitory concentration: 10300 nM
The estimate for compound 4 lay 4.9-fold (0.69 log units) above the measured number; the measured number lies below the stated range.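

In this assay, the change to 4-bromophenyl gives an at least 7.7-fold lower number from compound 3 to compound 4 (0.89 log units; beyond the scatter). Compound 4 is the first compound shown with 2-hydroxyethoxy to give a true number, so the aryl group on the aromatic carbon between two ring nitrogen atoms still matters with 2-hydroxyethoxy on the ring, whereas the only earlier readable step at this place came with chloro there. The size of this step is only a floor because compound 3 sits at a limit of the assay: the limit of > 80000 nM in this assay, at which 2 of the 4 values shown sit.

Going by these compounds, it remains open whether the bromine itself or its place on the phenyl ring drives the step, a question that 4-fluorophenyl or 2-bromophenyl at this position would address. On these data alone, it is also open how an amine or a longer chain in place of 2-hydroxyethoxy would read alongside 4-bromophenyl.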